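Dimethylamino in Place of Bromo: Compound 2 to Compound 3

The compounds below may be only part of what the source reports. "The series", "measured", "known", "first", "only" and "open" are said of these compounds alone.

Compound 1 `CC(=O)OCCOCn1cnc2c(Cl)ncnc21` gives 475 ug/mL in a functional assay on L1210 cells (Mus musculus) for inhibition; a lower number here means a stronger inhibitor, a higher number a weaker inhibitor. Going by these compounds, compound 2 `Nc1nc2c(nc(Br)n2COCCO)c(=O)[nH]1` reaches only a limit of the assay in this assay, namely > 500 ug/mL, so its exact position is unknown; this is the limit of > 500 ug/mL in this assay, at which 1 of the 2 values shown sits. Compound 3 `CN(C)c1nc2c(=O)[nH]c(N)nc2n1COCCO` differs from compound 2 in one respect: dimethylamino in place of bromo on an aromatic carbon. For the measured compounds named here, no measured pair shows what such a change does here, so no size is set for it. Compound 3 is expected to remain weak, with the step of an at least 1.1-fold lower number from compound 2 to compound 3 (0.04 log units; that floor lies within the scatter) not expected to exceed the scatter. In this assay compound 3 is estimated at 450 ug/mL, between 120 ug/mL and 1500 ug/mL.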

Compound 3, concentration for 50% inhibition: > 500 ug/mL
Compound 3: no number, only a limit; the forecaster's own chance of this, stated with the estimate: 60%; middle value at least 1.1-fold (0.04 log units) away from the limit.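

In this assay compound 3 gives > 500 ug/mL, which is a limit of the assay. Compound 2 also stands at a limit, so no step between compound 2 and compound 3 can be read: the limit of > 500 ug/mL in this assay, at which 2 of the 3 values shown sit.

The compounds shown leave open what dimethylamino in place of bromo does to inhibition, and where compound 2 and compound 3 truly stand.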